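Adding a methyl to the sulfonyl phenyl ring: expected stability

The source may report more compounds than this note shows. Statements on the series, on what has been measured and on what is new or still open speak of the compounds shown alone.

Measured so far in an ADME assay on microsomes from liver (Homo sapiens) for metabolic stability, with a stated time of 10 min; on this read-out lower numbers stand for a less stable compound and higher numbers for a more stable compound:
Compound 1 `CC(C)(C)OC(=O)NCCS(=O)(=O)NC(=O)c1ccc(Nc2nc(NC3(c4ccc(Cl)cc4)CC3)nc(OCC(F)(F)F)n2)cc1`: 92%
Compound 2 `O=C(NS(=O)(=O)c1ccccc1)c1ccc(Nc2nc(NC3(c4ccc(Cl)cc4)CC3)nc(OCC(F)(F)F)n2)cc1`: 100%

Both compounds share one core and differ only in the group on the sulfonyl sulfur, phenyl in place of 2-((tert-butoxycarbonyl)amino)ethyl. On the numbers shown, compound 2 and compound 1 cannot be told apart: the step of a number 8 percentage points higher from compound 1 to compound 2 (within the scatter) lies within the usual scatter, and both sit near the upper end of what this assay can report.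

Compound 3 `Cc1ccccc1S(=O)(=O)NC(=O)c1ccc(Nc2nc(NC3(c4ccc(Cl)cc4)CC3)nc(OCC(F)(F)F)n2)cc1` is not yet measured. For the measured compounds named here, it differs from compound 2 by methyl in place of hydrogen on an aromatic carbon; the change sits on the phenyl that was itself introduced in the single measured step. That step, a number 8 percentage points higher from compound 1 to compound 2 (within the scatter), is the only one available, and it is within the scatter, so nothing here points to a shift in either direction. The expectation for compound 3 is therefore a step of a number 6 percentage points lower from compound 2 to compound 3 (within the scatter), that is, no change beyond the scatter, with the range allowing only for the ceiling of the read-out. Compound 3 is estimated to give 94%, between 80% and 100%.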

Compound 3, percent of the compound remaining: 100%
Compound 3: middle estimate off by 6 percentage points, on the low side, within the range that was stated.
By their numbers in this assay, from the lowest: compounds 1, 2 and 3 (each within the scatter of the next).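

The step of no change at the digits printed from compound 2 to compound 3 (within the scatter) in this assay shows that a methyl can sit on this aromatic carbon, ortho to a large group, without a change beyond the scatter, which the phenyl of compound 2 alone could not show. The step of a number 8 percentage points higher from compound 1 to compound 3 (within the scatter) is also within the scatter, so on this read-out the 2-methylphenyl group, like phenyl, cannot be told apart from the 2-((tert-butoxycarbonyl)amino)ethyl group on the sulfonyl sulfur. No supporting data are available to explain why the methyl leaves the read-out as it is.

Compound 2 gives 100% and compound 3 gives 100% in this assay, so this percentage leaves no room to show any further gain in stability from the methyl, and a real difference between the two could stay hidden after this short incubation. On these data alone, it remains open whether a different group on this same carbon, such as a methoxy, a trifluoromethyl, an amine or a carboxylic acid, or a methyl elsewhere on the ring, would keep the number this high.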